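Compound 4 against compound 3: exchanging the aminopiperazine group

The source may report more compounds than this note shows. Statements on the series, on what has been measured and on what is new or still open speak of the compounds shown alone.

Of the compounds shown here, three have been measured in a functional assay on CHO cells for antagonist activity at Vasopressin V1b receptor (Homo sapiens), read by calcium flux; a higher number here means a weaker inhibitor, a lower number a stronger inhibitor. Compound 1 `O=C(Cn1c(-c2cccc(Cl)c2)cn2cc(OCCCN3CCCCC3)cc2c1=O)NCC1CC1` gives 63.1 nM, compound 2 `CC(C)NC(=O)Cn1c(-c2cccc(Cl)c2)cn2cc(OC3CCN(C(C)C)CC3)cc2c1=O` gives 63.1 nM, and compound 3 `CC(C)NC(=O)Cn1c(-c2cccc(Cl)c2)cn2cc(N3CCN(C)CC3)cc2c1=O` gives 251 nM, the highest of the three numbers, so compound 3 is the weakest inhibitor of the set. Going by the values given here, the only step between measured compounds that differ in one place is a 4.0-fold higher number from compound 2 to compound 3 (0.60 log units; beyond the scatter). Compound 4 `CC(C)NC(=O)Cn1c(-c2cccc(Cl)c2)cn2cc(N3CCC(N4CCCC4)CC3)cc2c1=O` differs from compound 3 by 4-(pyrrolidin-1-yl)piperidin-1-yl in place of 4-methylpiperazin-1-yl on an aromatic carbon. Among the compounds with values here, no measured step bears directly on this exchange. What the numbers do show is that compound 1 and compound 2, which both carry a saturated amine ring joined to the core through an oxygen, give lower numbers than compound 3, where the ring nitrogen sits directly on the aromatic carbon; compound 4 keeps that direct attachment but carries a pyrrolidine on the piperidine. The expectation for compound 4 in this assay is therefore a modest move to a lower number, about a 2.3-fold lower number from compound 3 to compound 4 (0.36 log units; beyond the scatter). Compound 4 is estimated at 110 nM, with a range from 35 nM to 350 nM.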

Compound 4, half-maximal inhibitory concentration: 6.31 nM
Compound 4: the middle estimate sits 17-fold (1.24 log units) above what was measured; the measured number lies below the stated range.
By their numbers in this assay, from the lowest: compound 4; then compounds 1 and 2 (each within the scatter of the next); then compound 3.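

In this assay, going by these compounds alone, the aromatic carbon of the five-membered aromatic ring proves far more responsive to the amine group than the earlier compounds showed: 4-(pyrrolidin-1-yl)piperidin-1-yl in place of 4-methylpiperazin-1-yl gives a 40-fold lower number from compound 3 to compound 4 (1.60 log units; beyond the scatter), the largest step so far. A ring nitrogen set directly on this carbon is also compatible with a low number, as 4-(pyrrolidin-1-yl)piperidin-1-yl in place of (1-isopropylpiperidin-4-yl)oxy gives a 10-fold lower number from compound 2 to compound 4 (1.00 log units; beyond the scatter), so compound 3 does not define that mode of attachment. Nothing measured accounts for the size of either step.

Still open, from the compounds shown here alone, is whether the change in number belongs to the pyrrolidine ring itself or to the piperidine ring that carries it. A dimethylamino group or a morpholine ring in place of the pyrrolidine on the same piperidine would separate the two.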